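The source may hold more compounds than are shown below. What is called first, only, known or untested is meant among the compounds shown, and "the series" means these compounds.

Of the compounds shown here, two have been measured so far. Among the measured compounds shown here, in a functional assay on HL-60 cells (Homo sapiens) for antiproliferative activity, read by MTT assay, with a stated time of 72 h (on this read-out higher numbers stand for weaker inhibition and lower numbers for stronger inhibition), compound 1 `CN(C(=O)c1ccco1)c1ccc2[nH]c(-c3n[nH]c4ccccc34)cc2n1` gives 4540 nM, and compound 2 `CN(c1ccc2[nH]c(-c3n[nH]c4ccccc34)cc2n1)S(=O)(=O)c1ccc(Cl)cc1` gives 770 nM, the lowest of the two numbers; the single measured step, a 5.9-fold lower number from compound 1 to compound 2 (0.77 log units; beyond the scatter), replaced the whole group on the ring nitrogen. Compound 3 `COc1ccc(S(=O)(=O)N(C)c2ccc3[nH]c(-c4n[nH]c5ccccc45)cc3n2)cc1OC` differs from compound 2 by 3,4-dimethoxyphenyl in place of 4-chlorophenyl on a sulfonyl sulfur. For the measured compounds named here, no measured step alters only the group on the sulfonyl sulfur, so that step offers no direct guide. Compound 3 is therefore expected to stay close to compound 2, and the expected step is a 1.6-fold higher number from compound 2 to compound 3 (0.19 log units; within the scatter). The estimate for compound 3 in this assay is 1200 nM, ranging from 400 nM to 4000 nM.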

Compound 3, half-maximal inhibitory concentration: 6320 nM
The estimate for compound 3 lay 5.3-fold (0.72 log units) below the measured number; measured number above the stated range.
By their numbers in this assay, from the lowest: compound 2; then compounds 1 and 3 (each within the scatter of the next).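

The group on the sulfonyl sulfur matters on its own: in this assay, 3,4-dimethoxyphenyl in place of 4-chlorophenyl gives an 8.2-fold higher number from compound 2 to compound 3 (0.91 log units; beyond the scatter). Keeping the sulfonyl link therefore does not by itself preserve the lower number of compound 2. No supporting measurement accounts for this shift.

Losing the chlorine and gaining the two methoxy groups happen in a single step, and their separate contributions remain open. On these data alone, how a plain phenyl group on the sulfonyl sulfur would compare also remains open.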